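Exchanging the five-membered ring of compound 1

This account rests on a few compounds, and the source may have more. Where it says the series, first, only, none or still open, it means among the compounds named here.

In an ADME assay on microsomes from liver (Homo sapiens) for metabolic stability (a higher number here means that the compound lasts longer, a lower number that the compound disappears faster), compound 1 (`CC(C)C(/C=C1\NC(=O)NC1=O)c1ccc(-c2ccc3cccc(F)c3c2)[nH]c1=O`) reads > 3 h and that is a limit of the assay, not a number. Compound 2 (`CC(C)[C@@H](c1ccc(-c2ccc3cccc(F)c3c2)[nH]c1=O)[C@@H]1OC(=O)NC1=O`) reads > 3 h and this too is only a limit. Compound 1 thus stands at the limit of > 3 h in this assay, at which 2 of the 3 values shown sit, and no exact half-life is known for it. In this assay compound 3 (`O=C1NC(=O)/C(=C/C(c2ccc(-c3ccc4cccc(F)c4c3)[nH]c2=O)C2CC2)O1`) gives 1.98 h as a real number with no limit attached.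

Within the data shown here, the one change from compound 1 to compound 4 (`CC(C)C(/C=C1\SC(=O)NC1=O)c1ccc(-c2ccc3cccc(F)c3c2)[nH]c1=O`) is a group of 8 heavy atoms (4 carbon, 1 nitrogen, 2 oxygen, 1 sulfur; one five-membered non-aromatic ring with 2 hetero atoms) in place of a group of 8 heavy atoms (4 carbon, 2 nitrogen, 2 oxygen; one five-membered non-aromatic ring with 2 hetero atoms), on a saturated chain carbon bound to an aromatic carbon and a saturated chain carbon and the rest of the structure stays the same. Among the measured compounds shown here, no pair of measured compounds shows this exchange on its own. The expectation rests on compound 3, which also carries a five-membered non-aromatic ring with 2 hetero atoms and gives 1.98 h in this series. No step beyond the usual scatter is expected in this assay for this exchange, and the expected at least 1.0-fold lower number from compound 1 to compound 4 (0.02 log units; that floor lies within the scatter) should be read that way. Compound 4 is estimated at 2.8 h with an expected range from 1.4 h to 5.5 h overall.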

Compound 4, half-life: > 3 h
Compound 4 gave a limit, no number; the forecaster's own chance of this, stated with the estimate: 40%; middle value at least 1.0-fold (0.02 log units) from the limit.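

In this assay compound 4 gives > 3 h, which is a limit of the assay and not a number. Compound 1 also stands at a limit, so no step can be read between compound 1 and compound 4. As far as these compounds go, how long either compound actually lasts remains open, and with it whether this ring exchange changes the half-life at all.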